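The source may report more compounds than this note shows. Statements on the series, on what has been measured and on what is new or still open speak of the compounds shown alone.

The compounds share one core and differ in the group on an amide-type nitrogen. Compound 1 `COc1ccc2c(=O)c(/C=C/C(=O)Nc3cccc(Cl)c3)coc2c1` carries a 3-chlorophenyl there, and in a functional assay on HeLa cells (Homo sapiens) for inhibition, read by MTT assay, with a stated time of 48 h (on this read-out higher numbers stand for weaker inhibition and lower numbers for stronger inhibition), compound 1 gives 11900 nM. Compound 2 `COc1ccc2c(=O)c(/C=C/C(=O)Nc3ccc(Cl)cc3)coc2c1` carries a 4-chlorophenyl in its place. For compound 2 only a limit is reported in this assay, namely > 100000 nM. Within the data shown here, the single measured step, an at least 8.4-fold higher number from compound 1 to compound 2 (0.92 log units; beyond the scatter), is the only guide to how the group on this nitrogen matters, and compound 2 stands at the limit of > 100000 nM in this assay, at which 1 of the 3 values shown sits. Among the measured compounds shown here, compound 3 `Cc1ccccc1NC(=O)/C=C/c1coc2cc(O)ccc2c1=O`, with a hydroxy on the core and a 2-methylphenyl on the nitrogen, gives 8670 nM in this assay; no one-place step connects it to compound 1 or compound 2.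

Compound 4 `COc1ccc2c(=O)c(/C=C/C(=O)NCc3ccccc3)coc2c1` has not yet been measured. It differs from compound 2 in one place:
benzyl in place of 4-chlorophenyl on an amide-type nitrogen
The step from compound 1 to compound 2 shows that the group on the nitrogen can move the result well beyond the scatter, but it concerns a chlorophenyl and says nothing about a benzyl, so its size cannot be carried over. Compound 2 stands at a limit, and the step of an at least 2.5-fold lower number from compound 2 to compound 4 (0.39 log units; beyond the scatter) that the estimate implies is therefore expected only loosely. Compound 4 is expected to give about 40000 nM in this assay, within a range from 8000 nM to 150000 nM.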

Compound 4, half-maximal inhibitory concentration: 33400 nM
The estimate for compound 4 lay 1.2-fold (0.08 log units) above the measured number; measured number inside the range.
By their numbers in this assay, from the lowest: compounds 3 and 1 (each within the scatter of the next); then compound 4. At a limit, above all of these: compound 2.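

The benzyl on the amide-type nitrogen brings the result back from the limit in this assay, with an at least 2.9-fold lower number from compound 2 to compound 4 (0.47 log units; beyond the scatter), yet it does not match the 3-chlorophenyl, with a 2.8-fold higher number from compound 1 to compound 4 (0.45 log units; beyond the scatter). Each of the three groups on this nitrogen therefore gives a result set apart from the other two beyond the scatter, even though 4-chlorophenyl and benzyl have the same heavy-atom count and one six-membered aromatic ring of carbon only, and differ in that benzyl has no chlorine and has its ring set one carbon further out from the nitrogen. The value of compound 2 is a limit and not a number, so the first of these steps has no upper end: the limit of > 100000 nM in this assay, at which 1 of the 4 values shown sits.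

The compounds shown leave open whether a chlorine on the benzyl ring, as in a 3-chlorobenzyl or a 4-chlorobenzyl, would bring the same difference as it does on the phenyl, and what a longer chain such as phenylethyl would give on this nitrogen. Among these compounds, they also leave open how the hydroxy on the core of compound 3 compares with the methoxy on the core of compound 1, since no one-place step connects the two.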